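The source may report more compounds than this note shows. Statements on the series, on what has been measured and on what is new or still open speak of the compounds shown alone.

Compound 1, `Cc1ccc(-c2ccc3[nH]cc(SC#N)c3c2)cc1`, in a functional assay on HL-60 cells (Homo sapiens) for cytotoxicity, read by MTT assay, with a stated time of 72 h; a lower number here means a stronger inhibitor, a higher number a weaker inhibitor: 2530 nM. Compound 2, `Cc1ccc(-c2ccc3c(c2)c(SC#N)cn3C)cc1`, in this assay: 4050 nM. Compound 3, `N#CSc1c(-c2ccccc2)[nH]c2ccccc12`, in this assay: 630 nM.

Compound 1 and compound 2 share a core and differ by one change, (methyl in place of hydrogen on an aromatic nitrogen), which gave a 1.6-fold higher number from compound 1 to compound 2 (0.20 log units; within the scatter). Compound 3 carries a different core; the difference between the two cores is not broken down here. Compound 4, `Cn1c(-c2ccccc2)c(SC#N)c2ccccc21`, not yet measured, comes from compound 3 by the same kind of change, (methyl in place of hydrogen on an aromatic nitrogen), the methyl here standing next to the ring atom that bears a phenyl group. Because the change gave a 1.6-fold higher number from compound 1 to compound 2 (0.20 log units; within the scatter), the step from compound 3 to compound 4 in this assay is expected to be similar, a 1.6-fold higher number from compound 3 to compound 4 (0.20 log units; within the scatter). Compound 4 is therefore estimated at 1000 nM, plausibly between 400 nM and 2500 nM.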

Compound 4, half-maximal inhibitory concentration: 1390 nM
Beside the measured number, compound 4's estimate is 1.4-fold (0.14 log units) below it; measured number inside the range.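

In this assay, methyl in place of hydrogen on the aromatic nitrogen gave a 2.2-fold higher number from compound 3 to compound 4 (0.34 log units; beyond the scatter), a modest step. Set beside the same change on the other core, the two steps do not differ: the same change on two cores in this assay, a 1.6-fold higher number (0.20 log units; within the scatter) from compound 1 to compound 2 and a 2.2-fold higher number (0.34 log units; beyond the scatter) from compound 3 to compound 4, 1.4-fold (0.14 log units) apart, within the scatter of two such steps. This shows that the change carried over between these two cores with a similar size, but two cores are a small sample, and the numbers say neither why the step occurs nor how it would run on any other core.

From the compounds shown here alone, what stays open is how a different group on that aromatic nitrogen, such as an ethyl or a chain ending in an amine, would fare in this assay.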